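Compound 2 and its chloro counterpart, compound 3

The compounds below may be only part of what the source reports. "The series", "measured", "known", "first", "only" and "open" are said of these compounds alone.

In a functional assay on K562 cells (Homo sapiens) for antiproliferative activity, read by MTT assay, with a stated time of 72 h (a higher number here means a weaker inhibitor, a lower number a stronger inhibitor), the measured compounds are:
Compound 1 `COc1cc(-n2ncnc2-c2ccc(C)cc2)cc(OC)c1OC` gives > 10000 nM as a limit of the assay
Compound 2 `CCOc1ccc(-c2ncnn2-c2cc(OC)c(OC)c(OC)c2)cc1Cl` gives 20 nM as a number

For the measured compounds named here, compound 2 holds the only number so far, at 20 nM. Compound 3 `COc1cc(-n2ncnc2-c2ccc(Cl)c(Cl)c2)cc(OC)c1OC` is still unmeasured and differs from compound 2 by one change, chloro in place of ethoxy on an aromatic carbon. Going by the values given here, no measured step shows this change, but a clear weakening beyond the scatter is expected in this assay. The expected step runs a 50-fold higher number from compound 2 to compound 3 (1.70 log units; beyond the scatter) in this estimate. For compound 3 the expected value is 1000 nM, with an estimated range from 60 nM to 10000 nM.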

Compound 3, half-maximal inhibitory concentration: > 10000 nM
Compound 3: no number, only a limit (the forecaster's own chance of this, stated with the estimate: 25%); middle value at least 10-fold (1.00 log units) from the limit.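

Replacing ethoxy with chloro on this aromatic carbon, ortho to a chloro group and para to a large group, gives an at least 500-fold higher number from compound 2 to compound 3 (2.69 log units; beyond the scatter) in this assay. This is the first single-place comparison shown, and it ties the activity of compound 2 to the ethoxy group at this position. The step is only a minimum, as compound 3 gives a limit and not a number: the limit of > 10000 nM in this assay, at which 2 of the 3 values shown sit.

The step from compound 1 to compound 3 cannot be read, as both values are limits. On these data alone, whether methoxy, propoxy or an amine at this carbon would keep the activity remains open.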